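Methyl for Chlorine on the Benzyl Group

A few compounds are considered here, and "the series" means these few. Any claim that something is new, unique, unknown or untested is made for them only; others in the source may bear on it.

For the measured compounds named here, in an assay on isolated protein for displacement of a labelled ligand from D(4) dopamine receptor (Homo sapiens) (a higher number here means a weaker inhibitor, a lower number a stronger inhibitor), compound 2 `O=C(NC1CCN(Cc2ccc(Cl)cc2)CC1)c1ccc2ccccc2c1` gives 37 nM, the lower of the two numbers measured so far. Compound 1 `COc1ccc(CN2CCC(NC(=O)c3cccc4ccccc34)CC2)cc1` gives 223 nM in this assay, a gap beyond the usual scatter. Compound 3 `Cc1cccc(CN2CCC(NC(=O)c3ccc4ccccc4c3)CC2)c1` has not yet been measured; it differs from compound 2 by 3-methylphenyl in place of 4-chlorophenyl on a saturated chain carbon bound to an amine nitrogen in a ring. Going by the values given here, no measured pair shows this exact change, so its size is uncertain, and a modest loss is expected, a step of a 2.4-fold higher number from compound 2 to compound 3 (0.39 log units; beyond the scatter) from compound 2 to compound 3. The estimate for compound 3 in this assay is 90 nM, with a range from 30 nM to 270 nM.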

Compound 3, inhibition constant: 11 nM
Compound 3: middle estimate off by 8.2-fold (0.91 log units), on the high side, and the stated range ends above it.
By their numbers in this assay, from the lowest: compound 3; then compound 2; then compound 1.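

Replacing 4-chlorobenzyl with 3-methylbenzyl gives a 3.4-fold lower number from compound 2 to compound 3 (0.53 log units; beyond the scatter) in this assay on the shared core. The chlorine of compound 2 is therefore not needed for a low number at this place, and a benzyl group carrying only carbon does better here. The change alters both the group and its ring position at once, so the compounds shown cannot separate the two, and how a trifluoromethyl group or an amine on this benzyl ring would fare stays open. Nothing given here explains the gain.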